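Removing one phenyl from compound 3: expectation for compound 4

The source may report more compounds than this note shows. Statements on the series, on what has been measured and on what is new or still open speak of the compounds shown alone.

Measured so far in an assay on microsomes from liver for inhibition of sterol O-acyltransferase 1 (Rattus norvegicus), tested at 50 ug/mL; a higher number here means more inhibition at the concentration tested (going by the name of the read-out), a lower number less inhibition:
compound 1 `CCCCCCCN(CCCCCSc1cc(-c2ccccc2)c(-c2ccccc2)nn1)C(=O)Nc1ccc(F)cc1F`: 75%
compound 2 `CCCCCCCN(CCCCC[S+]([O-])c1ccc(-c2ccccc2)nn1)C(=O)Nc1ccc(F)cc1F`: 55%
compound 3 `CCCCCCCN(CCCCCS(=O)(=O)c1cc(-c2ccccc2)c(-c2ccccc2)nn1)C(=O)Nc1ccc(F)cc1F`: 70%

Compound 3 holds the second highest of the three numbers. Its nearest neighbour is compound 1, whose number is higher by an amount within the usual scatter, so no order between compound 1 and compound 3 can be claimed. The furthest is compound 2, whose number lies lower by an amount beyond the scatter; compound 2 and compound 3 differ in two places, so only the two values themselves are known, not a single step.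

Compound 4 `CCCCCCCN(CCCCCS(=O)(=O)c1ccc(-c2ccccc2)nn1)C(=O)Nc1ccc(F)cc1F` has not been measured in this assay. It differs from compound 3 in one place: hydrogen in place of phenyl on an aromatic carbon. Compound 2 also carries hydrogen at that ring carbon and gives 55%, so a downward step beyond the scatter is expected. The step from compound 3 to compound 4 is estimated as a number 12 percentage points lower from compound 3 to compound 4 (beyond the scatter). Compound 4 is therefore expected to give about 58%, in the range 42% to 72%.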

Compound 4, a percentage reported as inhibition, at one concentration (the size of the read-out at that concentration, not a potency): 43%
For compound 4 the middle estimate is 15 percentage points above the measured one; low and high end bracket the measured number.
By their numbers in this assay, from the lowest: compound 4; then compound 2; then compounds 3 and 1 (each within the scatter of the next).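

Hydrogen in place of phenyl on this aromatic carbon, ortho to a phenyl group, gives a number 27 percentage points lower from compound 3 to compound 4 (beyond the scatter) in this assay as the first step in the series that can be read across a single change. The phenyl at this position therefore counts towards the inhibition seen at the concentration tested, at least in this one pair. Nothing at hand bears on the reason for this step.

As far as these compounds go, whether a smaller replacement on this carbon, such as a methyl group, a methoxy group or an amine, keeps inhibition at the level of compound 3 stays open. Also open, from the compounds shown here alone, is whether the same replacement of phenyl by hydrogen gives a step of similar size when made on compound 1.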